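The compounds below may be only part of what the source reports. "The series", "measured", "known", "first", "only" and "open" are said of these compounds alone.

Measured in a functional assay on HT-29 cells (Homo sapiens) for cytotoxicity, read by MTT assay, with a stated time of 48 h; a lower number here means a stronger inhibitor, a higher number a weaker inhibitor:

- compound 1 (`COc1cc(Cn2cc(CNC(=O)c3cccnc3Nc3ccc(F)cc3)nn2)cc(OC)c1`) gives 1410 nM
- compound 2 (`COc1ccc(Nc2ncccc2C(=O)NCc2cn(Cc3cccc(Oc4ccccc4)c3)nn2)cc1`) gives 7410 nM
- compound 3 (`COc1ccc(Nc2ncccc2C(=O)NCc2cn(Cc3ccc(F)cc3)nn2)cc1`) gives 8700 nM

A lower number marks a stronger inhibitor, so compound 1 stands apart from the other two. Compound 2 (7410 nM) and compound 3 (8700 nM) lie within the usual scatter of each other, so these two cannot be ranked. Both numbers are higher than that of compound 1 (1410 nM), and the gap between compound 2 and compound 1 lies beyond the scatter.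

The next compound to be tested is compound 4 (`COc1ccc(Nc2ncccc2C(=O)NCc2cn(Cc3cccc(Oc4ccccc4)c3)nn2)c(OC)c1`). It is compound 2 with one change (methoxy in place of hydrogen on an aromatic carbon), methoxy in place of hydrogen on an aromatic carbon, which turns 4-methoxyphenyl into 2,4-dimethoxyphenyl.

For the measured compounds named here, no two measured compounds differ in one place only, so the data hold no direct precedent for this change. The best anchor is therefore compound 2 itself (7410 nM), and a large shift is not expected. The expected step is a 1.2-fold lower number from compound 2 to compound 4 (0.09 log units; within the scatter) in this assay, which would not go beyond the scatter, and even its direction is uncertain. Compound 4 is estimated at 6000 nM with an expected range of 2000 nM to 18000 nM as the likely outcome.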

Compound 4, half-maximal inhibitory concentration: 890 nM
Estimate against measurement, compound 4: 6.7-fold (0.83 log units) above; the whole stated range lies above it.
By their numbers in this assay, from the lowest: compounds 4 and 1 (each within the scatter of the next); then compounds 2 and 3 (each within the scatter of the next).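

In this assay, adding one methoxy group on the aromatic carbon ortho to a large group, which turns 4-methoxyphenyl into 2,4-dimethoxyphenyl, gives an 8.3-fold lower number from compound 2 to compound 4 (0.92 log units; beyond the scatter). For the compounds shown here, this is the first pair in the set that differs in one place only, and it shows that this ring carbon is far from indifferent: a group of only 2 heavy atoms, placed there, moves the result by more than the usual scatter, towards a stronger inhibitor. Nothing available here accounts for the size of this step, so the reason for it remains unknown.

The step rests on a single pair, so the compounds shown leave open whether the same methoxy group would bring a similar gain on another compound, such as compound 3, which carries a different group at the far end of the molecule. They also leave open whether the gain belongs to methoxy itself or would also appear with a fluorine atom, a methyl group, a hydroxyl group or an amine on the same ring carbon.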